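A few compounds are considered here, and "the series" means these few. Any claim that something is new, unique, unknown or untested is made for them only; others in the source may bear on it.

Measured so far in a physicochemical assay for solubility, at pH 7.4; a higher number here means a more soluble compound, a lower number a less soluble compound:
compound 1, `Cc1cc(NC(=O)Nc2ccc(C)c(Cl)c2)c2ccccc2n1`, gives 300 nM
compound 2, `CCc1ccc(NC(=O)Nc2cc(C)nc3ccccc23)cc1`, gives 3300 nM
compound 3, `Cc1cc(NC(=O)Nc2cc(F)cc(F)c2)c2ccccc2n1`, gives 300 nM

Compound 2 stands highest of the three numbers; compound 1 and compound 3 both lie beyond the scatter below it. Compound 4, `Cc1cc(NC(=O)Nc2ccc(SC(F)(F)F)cc2)c2ccccc2n1`, has not yet been measured in this assay. It differs from compound 2 in one place: (trifluoromethyl)sulfanyl in place of ethyl on an aromatic carbon. Among the measured compounds shown here, no step between two measured compounds covers this change, so the size of the step is uncertain. Halogen-bearing partners in compound 1 and compound 3 sit well below compound 2, which points toward a downward step. Compound 4 is expected at 800 nM, within 200 nM to 3000 nM, a step of a 4.1-fold lower number from compound 2 to compound 4 (0.62 log units; beyond the scatter) estimated to fall below compound 2 but not to the floor of compound 1 and compound 3.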

Compound 4, solubility: 200 nM
Compound 4: middle estimate off by 4.0-fold (0.60 log units), on the high side; measured number inside the range.
By their numbers in this assay, from the lowest: compounds 4, 1 and 3 (each within the scatter of the next); then compound 2.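

In this assay, the change from ethyl to (trifluoromethyl)sulfanyl on an aromatic carbon, para to a large group, gives the series its first one-place step, a 17-fold lower number from compound 2 to compound 4 (1.22 log units; beyond the scatter), and it is large. Exchanging this one group is therefore enough to move the read-out well beyond the scatter. Nothing at hand accounts for the size of this step.

From the compounds shown here alone, it remains open whether the step follows the sulfur, the fluorines or the number of heavy atoms. Trifluoromethyl, methoxy or an amine on the same carbon would separate these.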